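Adding bromo to the phenyl of compound 2

The source may hold more compounds than are shown below. What is called first, only, known or untested is meant among the compounds shown, and "the series" means these compounds.

For the measured compounds named here, in a functional assay on NCI-N87 cells (Homo sapiens) for antiproliferative activity (on this read-out lower numbers stand for stronger inhibition and higher numbers for weaker inhibition), compound 2 (`NC1CCN(Cc2ccn3ncnc(Nc4ccccc4)c23)CC1`) gives 140 nM and holds the lower of the two numbers so far. Compound 1 (`C#Cc1cccc(Nc2ncnn3ccc(COC[C@@H]4CNCCO4)c23)c1`) gives 4400 nM on the same read-out, a gap beyond the scatter. Compound 3 (`NC1CCN(Cc2ccn3ncnc(Nc4cccc(Br)c4)c23)CC1`) differs from compound 2 by phenyl to 3-bromophenyl, bromo in place of hydrogen on an aromatic carbon. Going by the values given here, no measured pair shows this change, so any expectation remains loose. The expected step is a 2.3-fold lower number from compound 2 to compound 3 (0.37 log units; beyond the scatter) towards stronger inhibition and modest in size. The estimated value in this assay for compound 3 is 60 nM within an expected range of 15 nM to 250 nM for now.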

Compound 3, half-maximal inhibitory concentration: 50 nM
Estimate against measurement, compound 3: 1.2-fold (0.08 log units) above; the measured number falls inside the stated range.
By their numbers in this assay, from the lowest: compound 3; then compound 2; then compound 1.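

In this assay, for the compounds shown here, bromo in place of hydrogen on an aromatic carbon gives a 2.8-fold lower number from compound 2 to compound 3 (0.45 log units; beyond the scatter) and is the only single-place step so far. This position on the phenyl therefore accepts bromo with no loss of inhibition, and the number moves towards stronger inhibition. Nothing at hand explains the step. The compounds shown leave open whether the step belongs to bromo itself or would also appear with chloro, methyl or methoxy on the same carbon.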